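The source may report more compounds than this note shows. Statements on the series, on what has been measured and on what is new or still open speak of the compounds shown alone.

Measured so far in an ADME assay on PBMC cells (Homo sapiens) for cytotoxicity, read by MTT assay, with a stated time of 24 h; a higher number here means a weaker inhibitor, a lower number a stronger inhibitor:
- compound 1 `COc1cc(C)cc2c1C(=O)C=C(c1c(C)cc3c(c1OC)C(=O)C(NCc1ccccc1)=CC3=O)C2=O` gives > 100000 nM as a limit
- compound 2 `COc1cc(C)cc2c1C(=O)C=C(c1c(C)cc3c(c1OC)C(=O)C(N)=CC3=O)C2=O` gives > 100000 nM as a limit

Neither entry is a number, and compound 2 has no measured value to serve as a firm starting point. Compound 3 `COc1cc(C)cc2c1C(=O)C=C(c1c(C)cc3c(c1OC)C(=O)C(NC(C)=O)=CC3=O)C2=O` differs from it by acetyl in place of hydrogen on an amine nitrogen, amino to acetamido, and acetyl in place of hydrogen on an amine nitrogen gives the counted difference.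

For the measured compounds named here, one measured step bears on this change, since it also concerns an amine nitrogen: a step that the two limits leave unreadable from compound 1 to compound 2 offers no size to carry over. The remaining evidence is the limit of > 100000 nM in this assay, at which 2 of the 2 values shown sit, and it gives no direction either. No step beyond the scatter is therefore expected in this assay and no direction is predicted. The estimated step of a number no higher from compound 2 to compound 3 (the limit leaves the size open) is expected to be small or unreadable. This expectation rests on compound 2 with its limit of > 100000 nM as the nearest reference. For compound 3 the expected value is 100000 nM with an estimated range from 50000 nM to 200000 nM and a report as a limit is the likeliest outcome.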

Compound 3, half-maximal inhibitory concentration: 86500 nM
Compound 3: middle estimate off by 1.2-fold (0.06 log units), on the high side; the range from low to high includes it.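

In this assay, for the compounds shown here, compound 3 gives 86500 nM, the first number rather than a limit, so a group on this amine nitrogen now has a readable value. Acetyl in place of hydrogen gives an at least 1.1-fold lower number from compound 2 to compound 3 (0.06 log units; that floor lies within the scatter), and acetyl in place of benzyl gives an at least 1.1-fold lower number from compound 1 to compound 3 (0.06 log units; that floor lies within the scatter); each is only a floor, so the true size of both steps stays open, and neither floor alone establishes a change beyond the scatter. The series therefore still offers little numerical contrast at this position, with one number set against two limits: the limit of > 100000 nM in this assay, at which 2 of the 3 values shown sit.

The step between the benzyl and unsubstituted amine compounds cannot be read, so the two non-acylated groups cannot be ordered against each other. As far as these compounds go, it remains open whether a longer acyl chain, a sulfonamide or a carboxylic acid on this amine nitrogen would give a number clearly lower than that of compound 3 in this assay, or whether the series stays close to the limit whatever group is placed there.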